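Swapping an acetamidoethyl sulfonyl group for a tolyl sulfonyl group

A few compounds are considered here, and "the series" means these few. Any claim that something is new, unique, unknown or untested is made for them only; others in the source may bear on it.

Measured so far:
- compound 1, `CC(C)C(=O)NCCS(=O)(=O)NC(=O)c1ccc(Nc2nc(NC3(c4ccc(Cl)cc4)CC3)nc(OCC(F)(F)F)n2)cc1`: 13 nm/s
- compound 2, `CC(=O)NCCS(=O)(=O)NC(=O)c1ccc(Nc2nc(NC3(c4ccc(Cl)cc4)CC3)nc(OCC(F)(F)F)n2)cc1`: 7 nm/s

Both compounds share one core and were tested in a physicochemical assay for permeability, using PAMPA, at pH 7.4; a lower number here means that the compound crosses the layer more slowly, a higher number that the compound crosses the layer faster. Compound 2, with its value of 7 nm/s, has the lower of the two numbers, but the step of a 1.9-fold lower number from compound 1 to compound 2 (0.27 log units; within the scatter) is within the scatter, so the two compounds cannot be told apart.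

Compound 3, `Cc1ccccc1S(=O)(=O)NC(=O)c1ccc(Nc2nc(NC3(c4ccc(Cl)cc4)CC3)nc(OCC(F)(F)F)n2)cc1`, is not yet measured. It differs from compound 2 by 2-methylphenyl in place of 2-acetamidoethyl on a sulfonyl sulfur. For the measured compounds named here, the only measured step, a 1.9-fold lower number from compound 1 to compound 2 (0.27 log units; within the scatter), alters a group on a carbonyl carbon, not the group on the sulfonyl sulfur, so it does not directly inform this change. With no measured guidance, the expectation for compound 3 in this assay is a moderate rise, estimated as a 4.3-fold higher number from compound 2 to compound 3 (0.63 log units; beyond the scatter), with wide uncertainty. Compound 3 is thus expected to give 30 nm/s, within a range of 8 nm/s to 110 nm/s.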

Compound 3, apparent permeability: 265 nm/s
Estimate against measurement, compound 3: 8.8-fold (0.95 log units) below; the whole stated range lies below it.
By their numbers in this assay, from the lowest: compounds 2 and 1 (each within the scatter of the next); then compound 3.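

On the sulfonyl sulfur, the choice of group has a large effect in (this assay): 2-methylphenyl in place of 2-acetamidoethyl gives a 38-fold higher number from compound 2 to compound 3 (1.58 log units; beyond the scatter) and in place of the 2-((isopropylcarbonyl)amino)ethyl group gives a 20-fold higher number from compound 1 to compound 3 (1.31 log units; beyond the scatter) in the same direction. The earlier step altered only the end of the chain and stayed within the scatter, whereas replacing the whole chain moves the number well beyond it. The new group has an aromatic ring of carbon only and no hydrogen-bond donor or acceptor, but no available evidence links the rise to any one of these differences.

The compounds shown leave open whether the ring, its methyl or the absence of the amide matters most. A plain phenyl group or a butyl chain on the same sulfur would help separate these possibilities.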